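The source may report more compounds than this note shows. Statements on the series, on what has been measured and on what is new or still open speak of the compounds shown alone.

Measured so far:
Compound 1 `CC(C)(C)OC(=O)N1CCCN(CCCCCOc2c(Br)cc(Br)cc2Oc2ccc(Br)cc2Br)CC1` gives 39.5 ug/mL
Compound 2 `CCOC(=O)C(C)Oc1c(Br)cc(Br)cc1Oc1ccc(Br)cc1Br` gives 39.5 ug/mL

In a functional assay on U-937 cells (Homo sapiens) for cytotoxicity, read by MTT assay, with a stated time of 24 h (a lower number here means a stronger inhibitor, a higher number a weaker inhibitor), compound 2 stands at 39.5 ug/mL and is level with compound 1 at 39.5 ug/mL on these numbers. Compound 3 `Brc1ccc(Oc2cc(Br)cc(Br)c2OCc2ccccc2)c(Br)c1` is not yet measured. It carries benzyl in place of 1-(ethoxycarbonyl)ethyl on an oxygen on an aromatic ring, counted in full as benzyl in place of 1-(ethoxycarbonyl)ethyl on an oxygen on an aromatic ring here. Among the measured compounds shown here, no step between measured compounds exists to size this change, so compound 2 at 39.5 ug/mL is the only guide, and no shift beyond the scatter is expected. The expected 1.1-fold lower number from compound 2 to compound 3 (0.05 log units; within the scatter) is therefore small. Compound 3 is estimated at 35 ug/mL with a likely range from 15 ug/mL to 75 ug/mL in this test.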

Compound 3, half-maximal inhibitory concentration: 29 ug/mL
Beside the measured number, compound 3's estimate is 1.2-fold (0.08 log units) above it; low and high end bracket the measured number.
By their numbers in this assay, from the lowest: compounds 3, 1 and 2 (each within the scatter of the next).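

In this assay the exchange of 1-(ethoxycarbonyl)ethyl for benzyl, on an oxygen on an aromatic ring, gives a 1.4-fold lower number from compound 2 to compound 3 (0.13 log units; within the scatter) and so stays within the scatter. At this position, a group with no ring and two hydrogen-bond acceptors and a group with a six-membered aromatic ring and none therefore read alike in this test. Nothing available explains this result.

As far as these compounds go, whether a carboxylic acid or a plain hydroxyl on this oxygen would move the number beyond the scatter stays open.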